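A Methylcarbamoyl Group Added to Compound 2

The source may report more compounds than this note shows. Statements on the series, on what has been measured and on what is new or still open speak of the compounds shown alone.

Compound 1, `C[C@@H](Nc1c(C(N)=O)cnc2ccc(C#N)cc12)c1ccc(Cl)cc1`, in an assay on HT-29 cells for inhibition of Serine-protein kinase ATM (Homo sapiens), read by fluorescence, with a stated time of 1 h (a lower number here means a stronger inhibitor, a higher number a weaker inhibitor), gives 14400 nM.
Compound 2, `C[C@@H](Nc1ccnc2ccc(-c3cccnc3)cc12)c1ccc(Cl)cc1`, gives only a limit of the assay, > 30000 nM.

From the compounds shown here alone, compound 2 thus sits at the limit of > 30000 nM in this assay, at which 1 of the 2 values shown sits, so its true strength is unknown. Compound 3, `CNC(=O)c1cnc2ccc(-c3cccnc3)cc2c1N[C@H](C)c1ccc(Cl)cc1`, differs from compound 2 in one place: methylcarbamoyl in place of hydrogen on an aromatic carbon. Among the compounds with values here, no pair of measured compounds isolates this change, and compound 1 differs from both in two places, so the direction rests on little. Still, compound 3 is expected to give a lower number than compound 2, a step of an at least 3.7-fold lower number from compound 2 to compound 3 (0.57 log units; beyond the scatter). The estimate for compound 3 is 8000 nM, within 1500 nM to 30000 nM.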

Compound 3, half-maximal inhibitory concentration: > 30000 nM
Compound 3: no number, only a limit (the forecaster's own chance of this, stated with the estimate: 30%); at least 3.7-fold (0.57 log units) between middle value and limit.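

No step can be read from compound 2 to compound 3, because each gives only a limit, not a number: the limit of > 30000 nM in this assay, at which 2 of the 3 values shown sit.

From the compounds shown here alone, whether methylcarbamoyl in place of hydrogen on an aromatic carbon changes the true strength of compound 2 remains open.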